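This account rests on a few compounds, and the source may have more. Where it says the series, first, only, none or still open, it means among the compounds named here.

Measured compounds:
Compound 1 `O=C(O)c1ccccc1C1CC(c2cc3ccccc3o2)=NN1C(=O)c1ccncc1` in an ADME assay on Vero cells (Chlorocebus sabaeus) for cytotoxicity, read by MTT assay, with a stated time of 72 h (on this read-out lower numbers stand for stronger inhibition and higher numbers for weaker inhibition), gives only a limit, > 170000 nM.
Compound 2 `O=C(c1ccncc1)N1N=C(c2cc3ccccc3o2)CC1c1ccccc1Cl` in this assay gives only a limit, > 210000 nM.
Compound 3 `CCn1cc(C(=O)N2N=C(c3cc4ccccc4o3)CC2c2ccccc2C(=O)O)c(=O)c2ccc(C)nc21` in this assay gives only a limit, > 196000 nM.

Among the compounds with values here, compound 3 therefore stands at a limit in this assay, as do the other two values shown; every value in the set is a limit (the limit of > 170000 nM in this assay, at which 1 of the 3 values shown sits, (the limit of > 196000 nM in this assay, at which 1 of the 3 values shown sits), (the limit of > 210000 nM in this assay, at which 1 of the 3 values shown sits)), so no compound can be placed above or below another.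

Compound 4 `CCn1cc(C(=O)N2N=C(c3cc4ccccc4o3)CC2/C=C/c2ccccc2)c(=O)c2ccc(C)nc21` is not yet measured. It differs from compound 3 as follows: 2-phenylethenyl in place of 2-carboxyphenyl on a saturated ring carbon.

Within the data shown here, only one measured step exists, a step that the two limits leave unreadable from compound 1 to compound 2, and it is unreadable since both ends are limits. It concerns a different exchange on an aromatic carbon and does not bear on the change from compound 3 to compound 4. Among the measured compounds shown here, the expected size of a step that the limit leaves unreadable from compound 3 to compound 4 therefore rests on no step in the set, in either direction.

Given that compound 3 sits at a limit, compound 4 is expected to give a similarly high value in this assay, estimated at 200000 nM with a range of 80000 nM to 400000 nM, most likely again reported only as a limit.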

Compound 4, half-maximal inhibitory concentration: > 168000 nM
Compound 4 was reported as a limit; the forecaster's own chance of this, stated with the estimate: 80%; the middle value lies beyond the limit too.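

In this assay compound 4 gives only a limit, > 168000 nM. Within the data shown here, compound 3 also gives only a limit, > 196000 nM, so no step between compound 3 and compound 4 can be read. The compounds shown leave open whether 2-phenylethenyl in place of 2-carboxyphenyl changes the value in this assay at all.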